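The compounds below may be only part of what the source reports. "The series", "measured", "known", "first", "only" and "open" are said of these compounds alone.

Within the data shown here, in a functional assay on NCI/ADR-RES cells (Homo sapiens) for inhibition, read by sulforhodamine B assay, with a stated time of 48 h (on this read-out higher numbers stand for weaker inhibition of growth and lower numbers for stronger inhibition of growth), compound 2 `COc1ccc(/C=N/NC(=S)NC(C)(C)[C@H]2CC=C(C)CC2)cc1` gives 50400 nM, the only outright number among the three compounds measured so far. Compound 1 `CC1=CC[C@H](C(C)(C)N=C=S)CC1` reaches only a limit of the assay, > 100000 nM. Compound 3 `CC1=CC[C@H](C(C)(C)NC(=S)N/N=C/c2ccc(N(C)C)cc2)CC1` likewise stops at a limit, > 100000 nM. Among the measured compounds shown here, the single measured step, an at least 1.9-fold higher number from compound 2 to compound 3 (0.29 log units; that floor lies within the scatter), therefore ends at a limit (the limit of > 100000 nM in this assay, at which 2 of the 3 values shown sit), and its floor lies within the scatter of repeated measurements, so it shows no clear movement in either direction.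

Compound 4 `CC1=CC[C@H](C(C)(C)NC(=S)N/N=C/c2ccc[nH]2)CC1` has not yet been measured. Its change from compound 2 is 1H-pyrrol-2-yl in place of 4-methoxyphenyl on a carbon with a double bond to nitrogen. For the measured compounds named here, no measured step swaps the whole aromatic ring in this way, and the one step that alters the ring at all leaves the number within the scatter, so there is no ground to expect a large shift. The expected step, a 1.2-fold higher number from compound 2 to compound 4 (0.08 log units; within the scatter), is small, with a real chance that compound 4 reaches only a limit. Compound 4 is estimated at 60000 nM, within 15000 nM to 200000 nM, in this assay.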

Compound 4, concentration for total growth inhibition: > 100000 nM
Compound 4 ended at the assay's limit; the forecaster's own chance of this, stated with the estimate: 40%; middle value at least 1.6-fold (0.22 log units) away from the limit.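

Until now only a change on the aromatic ring had been seen; here the whole six-membered carbon ring gives way to a five-membered ring with one hetero atom and a hydrogen-bond donor, and this assay records an at least 1.9-fold higher number from compound 2 to compound 4 (0.29 log units; that floor lies within the scatter). So even this larger change at the carbon with a double bond to nitrogen shows no clear movement in either direction, and 4-methoxyphenyl remains the only group at this place that gives an outright number, that of compound 2. The read-out now offers little room to tell these compounds apart, with most values at a limit of the assay: the limit of > 100000 nM in this assay, at which 3 of the 4 values shown sit.

On these data alone, whether a 4-chlorophenyl or a pyridine ring at this place would give an outright number stays open. So does the effect of a carboxylic acid or an amine on the aromatic ring.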